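The source may report more compounds than this note shows. Statements on the series, on what has been measured and on what is new or still open speak of the compounds shown alone.

Compound 1 `CC1=C(C(=O)OCC2CCCCC2)C(c2cccc(O)c2)NC(=O)N1C`: in an ADME assay on CEMx174 cells (Homo sapiens) for cytotoxicity (a higher number here means that more compound is tolerated, a lower number that less compound is tolerated), compound 1 gives > 10000 nM, a limit of the assay.
Compound 2 `Cc1nc(=O)[nH]c(-c2cccc(O)c2)c1C(=O)OCC1CCCCC1`: in this assay compound 2 gives > 10000 nM, a limit of the assay.
Compound 3 `CCC1=C(C(=O)OCC2CCCCC2)C(c2ccc([N+](=O)[O-])cc2)NC(=O)N1`: in this assay compound 3 gives > 10000 nM, a limit of the assay.

Compound 3 stands at the limit of this assay, and the two other measured compounds stand there with it, all three at the limit of > 10000 nM in this assay, at which 3 of the 3 values shown sit. No number separates them, so none can be called better or worse tolerated than another on what is shown.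

Compound 4 `CCC1=C(C(=O)OCC2CCCCC2)C(c2ccc(Cl)cc2)NC(=O)N1` differs from compound 3 in one place: chloro in place of nitro on an aromatic carbon. Among the measured compounds shown here, no measured pair shows a change of this kind, so its size cannot be read from the data. For the measured compounds named here, the only guide is that compound 3 and the two other compounds sit at the limit of > 10000 nM in this assay, at which 3 of the 3 values shown sit. The step that the limit leaves unreadable from compound 3 to compound 4 is expected to stay within the scatter, with no clear direction. Compound 4 is therefore expected to sit at the limit as well, estimated at 15000 nM, within 8000 nM to 40000 nM, and most likely reported again only as a limit.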

Compound 4, half-maximal cytotoxic concentration: > 10000 nM
Compound 4: a limit, no number; the forecaster's own chance of this, stated with the estimate: 80%; the middle value lies beyond the limit too.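

No step can be read from compound 3 to compound 4, since both stand only as limits in this assay: the limit of > 10000 nM in this assay, at which 4 of the 4 values shown sit.

The compounds shown leave open how far each lies past that limit, and whether chloro in place of nitro changes how much compound is tolerated.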